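The source may hold more compounds than are shown below. What is called first, only, known or untested is meant among the compounds shown, and "the series" means these compounds.

Measured in a functional assay on SW-620 cells (Homo sapiens) for antiproliferative activity, read by MTT assay, with a stated time of 24 h; on this read-out higher numbers stand for weaker inhibition and lower numbers for stronger inhibition:
- Compound 1 `COc1ccc(C(=O)/C=C/c2cccc(F)c2)c2c1C=CC(C)(C)O2`: > 10000 nM (a limit)
- Compound 2 `COc1ccc(C(=O)/C=C/c2ccc(Br)cc2)c2c1C=CC(C)(C)O2`: > 10000 nM (a limit)
- Compound 3 `COc1ccc(C(=O)/C=C/c2ccc(-n3ccnc3)cc2)c2c1C=CC(C)(C)O2`: > 10000 nM (a limit)

Compound 2 has no number, only a limit, and it shares that position with both other compounds: the limit of > 10000 nM in this assay, at which 3 of the 3 values shown sit. Compound 4 `COc1ccc(C(=O)/C=C/c2ccsc2)c2c1C=CC(C)(C)O2` departs from compound 2 in one place: thiophen-3-yl in place of 4-bromophenyl on a double-bonded chain carbon bound to a double-bonded chain carbon. For the measured compounds named here, two measured steps bear on this change, a step that the two limits leave unreadable from compound 1 to compound 2 and a step that the two limits leave unreadable from compound 2 to compound 3. Going by the values given here, neither gives a size, so no measured step supports a shift in either direction in this assay. The expected result is a step that the limit leaves unreadable from compound 2 to compound 4, with no change beyond the scatter. For compound 4 the estimated value is 15000 nM. The expected range for compound 4 runs from 5000 nM to 40000 nM.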

Compound 4, half-maximal inhibitory concentration: > 10000 nM
Compound 4 ended at the assay's limit (the forecaster's own chance of this, stated with the estimate: 80%); the middle value is on the limit's open side.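

In this assay compound 4 gives > 10000 nM, a limit, so its steps from compound 1 and compound 2 cannot be read. Compound 1, compound 2, compound 3 and compound 4 leave open whether any of these groups shifts the activity, as all share one position: the limit of > 10000 nM in this assay, at which 4 of the 4 values shown sit.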